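A few compounds are considered here, and "the series" means these few. Any claim that something is new, unique, unknown or untested is made for them only; others in the source may bear on it.

Working notes on the shared core, followed in a functional assay on MGC-803 cells (Homo sapiens) for inhibition, read by sulforhodamine B assay; on this read-out lower numbers stand for stronger inhibition and higher numbers for weaker inhibition. Compound 1 `O=C1C(NC2CC2)=CC(=O)c2c1nc1n2[C@H]2OC[C@@H](O)[C@H]2OC1` carries a cyclopropylamino group and in this assay gives only a limit, > 4000 nM, as recorded in the limit of > 4000 nM in this assay, at which 1 of the 3 values shown sits. Compound 2 `O=C1C=C(Nc2ccccc2)C(=O)c2c1nc1n2[C@H]2OC[C@@H](O)[C@H]2OC1`, the anilino analogue, gives 1730 nM in this assay. Compound 3 `CCOc1ccc(NC2=CC(=O)c3nc4n(c3C2=O)[C@H]2OC[C@@H](O)[C@H]2OC4)cc1` gives 1110 nM in this assay, and a 1.6-fold lower number from compound 2 to compound 3 (0.19 log units; within the scatter), a change on the aryl ring without effect beyond the scatter. Compound 4 `O=C1C(Nc2ccc(I)cc2)=CC(=O)c2c1nc1n2[C@H]2OC[C@@H](O)[C@H]2OC1` is the next entry: 4-iodophenyl in place of cyclopropyl on an amine nitrogen. For the measured compounds named here, no measured step starts from a limit, so the size of this step cannot be read from the series; the two arylamines, compound 2 and compound 3, show where such analogues sit. Compound 4 is expected to land near them, at an estimated 1300 nM in this assay, within 500 nM to 3500 nM. The expected step is an at least 3.0-fold lower number from compound 1 to compound 4 (0.48 log units; beyond the scatter).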

Compound 4, half-maximal inhibitory concentration: 2150 nM
Compound 4: middle estimate off by 1.7-fold (0.22 log units), on the low side, within the range that was stated.
By their numbers in this assay, from the lowest: compounds 3, 2 and 4 (each within the scatter of the next). At a limit, above all of these: compound 1.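

In this assay, an at least 1.8-fold lower number from compound 1 to compound 4 (0.26 log units; that floor lies within the scatter) is the reading for 4-iodophenyl in place of cyclopropyl on the amine nitrogen. Compound 1 is held at a limit, so only a floor can be read for this step: the limit of > 4000 nM in this assay, at which 1 of the 4 values shown sits. Compounds 3, 2 and 4 each lie within the scatter of the next, so iodine on the aryl ring reads no differently from ethoxy or hydrogen.

Still open, going by these compounds, is how a benzyl group on the same nitrogen would read, and whether any aryl substituent, such as a carboxylic acid, moves the number beyond the scatter.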